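The source may hold more compounds than are shown below. What is called first, only, known or untested is meant among the compounds shown, and "the series" means these compounds.

Compound 1 `COc1ccc2oc(/C=C/c3ccc(OC(F)(F)F)cc3)cc(=O)c2c1` is assessed in a functional assay on A549 cells (Homo sapiens) for antiproliferative activity, read by MTT assay, with a stated time of 12 h; on this read-out lower numbers stand for stronger inhibition and higher numbers for weaker inhibition. In this assay compound 1 gives > 40000 nM, which is a limit of the assay rather than a number. Compound 2 `COc1ccc(/C=C/c2cc(=O)c3c(OC)cc(OC)cc3o2)cc1` is the other measured member of the series. In this assay compound 2 gives > 40000 nM, again a limit and not a number. Compound 1 thus stands at the ceiling shared by every value shown: the limit of > 40000 nM in this assay, at which 2 of the 2 values shown sit. Among the measured compounds shown here, no step between measured compounds is available.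

Compound 3 `O=c1cc(/C=C/c2ccc(OC(F)(F)F)cc2)oc2ccccc12` differs from compound 1 by hydrogen in place of methoxy on an aromatic carbon. For the measured compounds named here, no measured step shows what this change does in this assay, and both known values are limits, so no direction can be read from them. The step of a number no higher from compound 1 to compound 3 (the limit leaves the size open) is expected to be none beyond the scatter. Compound 3 is estimated at 40000 nM in this assay, within 10000 nM to 100000 nM, most likely reported once more only as a limit.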

Compound 3, half-maximal inhibitory concentration: 15600 nM
Beside the measured number, compound 3's estimate is 2.6-fold (0.41 log units) above it; low and high end bracket the measured number.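

Hydrogen in place of methoxy on this aromatic carbon gives an at least 2.5-fold lower number from compound 1 to compound 3 (0.40 log units; beyond the scatter), the only step in the series that can be read. Compound 3 gives 15600 nM in this assay, so the methoxy group at this place is not required for a measurable number, and the change moves the read-out beyond the scatter. On these data alone, compound 1 carries a limit and not a number, so the step fixes only a smallest size and its full size stays open.

As far as these compounds go, whether another group at this place, such as an amine, a carboxylic acid or a longer alkoxy chain, would hold or lower the number of compound 3 stays open, and a single step gives no rule for the series. Compound 2 has no partner differing in one place, and the other values add no number: the limit of > 40000 nM in this assay, at which 2 of the 3 values shown sit.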